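The source may hold more compounds than are shown below. What is called first, only, known or untested is meant among the compounds shown, and "the series" means these compounds.

Compound 1 `COc1cc2c(c(O)c1OC)C(=O)[C@]1(OC)C=C[C@H]2N(C(=O)OCC(C)C)N1C(=O)OCC(C)C` carries a free hydroxyl on one of its aromatic rings. In an ADME assay on KB cells (Homo sapiens) for cytotoxicity (a lower number here means that less compound is needed, a higher number that more compound is needed for the effect), compound 1 gives only a limit, > 300 ug/mL. Compound 3 `COc1ccc(COc2c(OC)c(OC)cc3c2C(=O)[C@]2(OC)C=C[C@H]3N(C(=O)OCC(C)C)N2C(=O)OCC(C)C)cc1` instead carries a 4-methoxybenzyl on that oxygen, and in this assay compound 3 gives 47.9 ug/mL, the lowest of the two measured numbers; compound 2 `CCOC(=O)N1[C@@H]2C=C[C@@](OC)(C(=O)c3c2cc(OC)c(OC)c3OCc2ccccc2F)N1C(=O)OCC`, another benzyl ether with ethyl carbamates, gives 99.7 ug/mL in this assay. For the measured compounds named here, the single measured step, an at least 6.2-fold lower number from compound 1 to compound 3 (0.79 log units; beyond the scatter), concerns the whole benzyl group rather than its substituent. Compound 4 `COc1cc2c(c(OCc3ccc(Cl)cc3)c1OC)C(=O)[C@]1(OC)C=C[C@H]2N(C(=O)OCC(C)C)N1C(=O)OCC(C)C` differs from compound 3 by chloro in place of methoxy on an aromatic carbon. Going by the values given here, no measured step covers swapping one substituent for another on that ring, and only a small shift is expected: a 1.1-fold lower number from compound 3 to compound 4 (0.03 log units; within the scatter). Compound 4 is estimated at 45 ug/mL, between 20 ug/mL and 100 ug/mL.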

Compound 4, concentration for half-maximal effect: 42 ug/mL
The estimate for compound 4 lay 1.1-fold (0.03 log units) above the measured number, and the stated range covers the measured number.
By their numbers in this assay, from the lowest: compounds 4 and 3 (each within the scatter of the next); then compound 2. At a limit, above all of these: compound 1.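

Chloro in place of methoxy on the benzyl ring gives a 1.1-fold lower number from compound 3 to compound 4 (0.06 log units; within the scatter) in this assay, so these two substituents cannot be told apart here. The gain from etherifying the hydroxyl therefore recurs with a second substituent, as an at least 7.1-fold lower number from compound 1 to compound 4 (0.85 log units; beyond the scatter). Compound 1 itself remains a limit of the assay rather than a number: the limit of > 300 ug/mL in this assay, at which 1 of the 4 values shown sits.

As far as these compounds go, what an amine or a carboxylic acid would give at this place on the benzyl ring stays open. So does the effect of a longer chain in place of the benzyl on that oxygen.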